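The compounds below may be only part of what the source reports. "The series", "measured", "known", "first", "only" and "open" are said of these compounds alone.

Compound 2 `CCOC(=O)c1c(-c2cccc(Cl)c2)[nH]c2cc(OC)c(Cl)cc2c1=O` sits at the top of what an ADME assay on BJ cells (Homo sapiens) for cytotoxicity, read by luminescence, with a stated time of 72 h (a higher number here means that more compound is needed for the effect, a lower number that less compound is needed), can report: compound 2 gives > 21500 nM, which is a limit and not a number. Compound 1 `CCOC(=O)c1c(-c2cc(F)cc(OC)c2)[nH]c2cc(OC)ccc2c1=O` is also known only as a limit, at > 21500 nM. Thus both values are bounds, (the limit of > 21500 nM in this assay, at which 2 of the 2 values shown sit), and neither compound has a measured number.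

Compound 3 `CCOC(=O)c1c(-c2cc(F)cc(OC)c2)[nH]c2cc(OC)c(Cl)cc2c1=O` keeps the core of compound 2 but carries 3-fluoro-5-methoxyphenyl in place of 3-chlorophenyl on an aromatic carbon, (3-fluoro-5-methoxyphenyl in place of 3-chlorophenyl on an aromatic carbon). Compound 1 carries the same 3-fluoro-5-methoxyphenyl group, and its reading is > 21500 nM, so no shift beyond the scatter is expected in this assay. The expected change, a step that the limit leaves unreadable from compound 2 to compound 3, is therefore small, and a further limit is the likeliest result. The estimate for compound 3 is 25000 nM, with an expected range of 12000 nM to 45000 nM.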

Compound 3, half-maximal effective concentration: > 21500 nM
Compound 3: a limit, no number (the forecaster's own chance of this, stated with the estimate: 85%); the middle value lies beyond the limit too.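

No step to compound 3 from compound 1 or compound 2 can be read: the limit of > 21500 nM in this assay, at which 3 of the 3 values shown sit.

The compounds shown leave open whether chloro in place of hydrogen, or 3-fluoro-5-methoxyphenyl in place of 3-chlorophenyl, shifts the reading in this assay at all.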